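Ethoxy to Methoxy on the Shared Core

This account rests on a few compounds, and the source may have more. Where it says the series, first, only, none or still open, it means among the compounds named here.

In a functional assay on KBVIN cells (Homo sapiens) for cytotoxicity, read by sulforhodamine B assay, with a stated time of 3 days (a higher number here means that more compound is needed for the effect, a lower number that less compound is needed), compound 3 (`CCOc1c(-c2occ(C)c2CO)ccc2c1CCCC2(C)C`) gives 15.3 uM and so sits within the scatter of compound 1 (`CCOCc1c(C)coc1-c1ccc2c(c1OC)CCCC2(C)C`) at 16.5 uM while compound 2 (`COc1c(-c2occ(C)c2C(=O)O)ccc2c1CCCC2(C)C`) gives 47.8 uM as the highest of the three numbers. Compound 4 (`COc1c(-c2occ(C)c2CO)ccc2c1CCCC2(C)C`) differs from compound 3 by hydrogen in place of methyl on a saturated chain carbon bound to an oxygen on an aromatic ring with hydrogen in place of methyl on a saturated chain carbon bound to an oxygen on an aromatic ring, which turns ethoxy to methoxy. Going by the values given here, the only measured step (a 2.9-fold higher number from compound 1 to compound 2 (0.46 log units; beyond the scatter)) is a different change, carboxy in place of ethoxymethyl on an aromatic carbon, and it bears on this one only weakly. No shift beyond the scatter is therefore expected in this assay, and the estimated step is small (a 1.2-fold higher number from compound 3 to compound 4 (0.07 log units; within the scatter)). Compound 4 is estimated at 18 uM (expected range 9 uM to 36 uM).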

Compound 4, concentration for half-maximal effect: 21.7 uM
For compound 4 the middle estimate is 1.2-fold (0.08 log units) below the measured one, within the range that was stated.
By their numbers in this assay, from the lowest: compounds 3, 1 and 4 (each within the scatter of the next); then compound 2.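

In this assay, ethoxy to methoxy gives a 1.4-fold higher number from compound 3 to compound 4 (0.15 log units; within the scatter) and so leaves no readable shift at this place on the shared core. The side chain shows the same for hydrogen in place of ethyl on an oxygen on a saturated carbon, with a 1.3-fold higher number from compound 1 to compound 4 (0.12 log units; within the scatter) as its step. Hydroxymethyl in place of carboxy is the one change here that goes beyond the scatter, with a 2.2-fold lower number from compound 2 to compound 4 (0.34 log units; beyond the scatter) as its step.

On these data alone, whether a chain longer than ethyl or an amine in this place would hold the number stays open. No measurement shown here gives a reason for any of these steps.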